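Solubility notes on a pyridyl-amine series

A few compounds are considered here, and "the series" means these few. Any claim that something is new, unique, unknown or untested is made for them only; others in the source may bear on it.

Among the compounds with values here, compound 1 `Cc1cc(NCCCc2ccccn2)n2nc(C)c(-c3ccccc3)c2n1` is the only member of the set with a numerical result: in a physicochemical assay for solubility, read by HPLC, using the shake flask method, measured as kinetic solubility, with a stated time of 2 h, at pH 7.4 (a higher number here means a more soluble compound, a lower number a less soluble compound), compound 1 gives 5900 nM. Compound 2 `Cc1cc(NCc2ccc3ccccc3n2)n2nc(C)c(-c3ccccc3)c2n1` reports only a limit of the assay, < 5000 nM. Compound 3 `Cc1cc(NCc2ccccn2)n2ncc(-c3ccc(F)c(Cl)c3)c2n1` likewise sits at the assay limit, < 5000 nM; two of the three values share this limit (the limit of < 5000 nM in this assay, at which 2 of the 3 values shown sit). Compound 4 `Cc1cc(NCc2ccc(F)cn2)n2nc(C)c(-c3ccccc3)c2n1` is not yet measured. It differs from compound 1 by 5-fluoropyridin-2-yl in place of 2-(pyridin-2-yl)ethyl on a saturated chain carbon bound to a nitrogen on an aromatic ring. Within the data shown here, no measured pair isolates this change, so the expectation rests only on compound 2 and compound 3 sitting at the limit (the limit of < 5000 nM in this assay, at which 2 of the 3 values shown sit). The step from compound 1 to compound 4 is expected to be downward, a 1.7-fold lower number from compound 1 to compound 4 (0.23 log units; within the scatter), beyond the scatter. Compound 4 is therefore expected to give about 3500 nM, within 1200 nM to 9000 nM, with a fair chance of only a limit being reported.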

Compound 4, solubility: < 5000 nM
Compound 4 was reported as a limit (the forecaster's own chance of this, stated with the estimate: 55%); the middle value is on the limit's open side.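

Within the data shown here, the first step at this position, on a saturated chain carbon bound to a nitrogen on an aromatic ring, reads an at least 1.1-fold lower number from compound 1 to compound 4 (0.07 log units; that floor lies within the scatter) and so fixes only a floor, not the true size of the change. Among these compounds, compound 1 remains the only member with a numerical result, and the (5-fluoropyridin-2-yl)methyl group brings no exception to the pattern at the assay limit: the limit of < 5000 nM in this assay, at which 3 of the 4 values shown sit.

This change alters the chain and the fluorine together, leaving the share of each unresolved. Going by these compounds, what an amine or a carboxylic acid at this position would give in this assay also stays open.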